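Side-chain amine exchange in the oxime series

This account rests on a few compounds, and the source may have more. Where it says the series, first, only, none or still open, it means among the compounds named here.

Compound 1 `C[n+]1ccn(CCC#N)c1/C=N/O` and compound 2 `CN(C)CCn1cc[n+](C)c1/C=N/O` share one core and differ only at the end of the chain. In a physicochemical assay for lipophilicity (a lower number here means a more polar compound, a higher number a more lipophilic compound), compound 1 gives -3.3; in this assay compound 2 gives -3.06. Within the data shown here, the single measured step, a number 0.24 log units higher from compound 1 to compound 2 (within the scatter), is the only comparison so far, so compound 2 stands within the scatter of compound 1 and the two numbers cannot be ordered.

Compound 3 `C[n+]1ccn(CCN2CCCC2)c1/C=N/O` is not yet measured. Its change from compound 2 is pyrrolidin-1-yl in place of dimethylamino on a saturated chain carbon, two bonds along the chain from an aromatic nitrogen. The step from compound 1 to compound 2 touches the same place but exchanges a nitrile for an amine, not one amine for another, so it bears on the new step only loosely; nothing measured here exchanges two amines. The step of a number 0.36 log units higher from compound 2 to compound 3 (beyond the scatter) is expected to be a small rise, near the edge of the scatter. Compound 3 is estimated at -2.7, within -3.1 to -2.3.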

Compound 3, distribution coefficient: -2.73
Compound 3: the middle estimate sits 0.03 log units above what was measured, and the stated range covers the measured number.
By their numbers in this assay, from the lowest: compounds 1 and 2 (each within the scatter of the next); then compound 3.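

In this assay the exchange of one amine for another on the chain gives a number 0.33 log units higher from compound 2 to compound 3 (beyond the scatter) and so shows that this place responds to the choice of amine, not only to the exchange of a nitrile for an amine. The earlier exchange of cyano for dimethylamino stayed within the scatter, whereas pyrrolidin-1-yl in place of cyano gives a number 0.57 log units higher from compound 1 to compound 3 (beyond the scatter) and so opens the first clear separation at the end of the chain. No measured information is at hand to account for either step.

On these data alone, whether the rise follows the ring itself or only the larger number of carbon atoms stays open, and diethylamino or piperidin-1-yl at the same place would help to separate the two readings. As far as these compounds go, how a longer chain carrying pyrrolidin-1-yl would read in this assay also remains open.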